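Chloro position shift on the aryl group of compound 3

The source may report more compounds than this note shows. Statements on the series, on what has been measured and on what is new or still open speak of the compounds shown alone.

Among the compounds with values here, compound 3 `Oc1cccc(-c2cc(-c3ccccc3)nc(-c3ccc(Cl)cc3)c2)c1` gives 7.1% in an assay on isolated protein for inhibition of DNA topoisomerase 1 (Homo sapiens), with a stated time of 30 min, tested at 100 uM (a lower number here means a weaker effect, a higher number a stronger effect of the compound at the concentration tested), the second highest of the three numbers so far: compound 1 `Oc1cccc(-c2cc(-c3ccc(Cl)cc3)nc(-c3cccnc3)c2)c1` gives 2.8%, within the scatter of compound 3, while compound 2 `Oc1cccc(-c2cc(-c3ccc(Cl)cc3)nc(-c3ccccn3)c2)c1` gives 30%, with a number 22.9 percentage points lower from compound 2 to compound 3 (beyond the scatter). Compound 4 `Oc1cccc(-c2cc(-c3ccccc3)nc(-c3cccc(Cl)c3)c2)c1` changes (3-chlorophenyl in place of 4-chlorophenyl on an aromatic carbon). Within the data shown here, none of the measured steps touches this group: a number 27.2 percentage points higher from compound 1 to compound 2 (beyond the scatter) and a number 4.3 percentage points higher from compound 1 to compound 3 (within the scatter) concern the other aromatic carbon of the shared core, and no comparison of chlorine positions exists. No step beyond the scatter is therefore expected for compound 4 in this assay; the expected change is a number 0.9 percentage points higher from compound 3 to compound 4 (within the scatter). Compound 4 is estimated at 8%, with a range from 0% to 25%.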

Compound 4, a percentage reported as inhibition, at one concentration (the size of the read-out at that concentration, not a potency): 11.5%
Compound 4: the middle estimate sits 3.5 percentage points below what was measured, within the range that was stated.
By their numbers in this assay, from the lowest: compounds 1, 3 and 4 (each within the scatter of the next); then compound 2.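

Moving the chlorine, with 3-chlorophenyl replacing 4-chlorophenyl next to the ring nitrogen, gives in this assay a number 4.4 percentage points higher from compound 3 to compound 4 (within the scatter). This first comparison of chlorine positions therefore shows no readable effect of the shift at this aromatic carbon, at the single concentration tested. Nothing available bears on why the two chlorophenyl groups read alike.

Open, on these data alone, is whether an amine or a carboxylic acid in place of the chlorine would move the number beyond the scatter. Also open, as far as these compounds go, is whether the chlorine shift would read the same with pyridin-2-yl in place of the phenyl group, the change present in compound 2 at 30%.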